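From Methyl to Methoxy in the Series

The source may report more compounds than this note shows. Statements on the series, on what has been measured and on what is new or still open speak of the compounds shown alone.

Among the measured compounds shown here, in a functional assay on PANC-1 cells (Homo sapiens) for cytotoxicity, read by MTT assay, with a stated time of 68 h (a higher number here means a weaker inhibitor, a lower number a stronger inhibitor), compound 1 `O=C(/C=C/c1cccc(OCc2ccccc2)c1)c1ccc([N+](=O)[O-])cc1` gives 25400 nM and compound 2 `Cc1ccc(C(=O)/C=C/c2cccc(OCc3ccccc3)c2)cc1` gives 41600 nM, so compound 2 stands within the scatter of the only other measured compound. Compound 3 `COc1ccc(C(=O)/C=C/c2cccc(OCc3ccccc3)c2)cc1` differs from compound 2 by methoxy in place of methyl on an aromatic carbon. For the measured compounds named here, one measured step bears on this change, a 1.6-fold higher number from compound 1 to compound 2 (0.21 log units; within the scatter), and it swaps methyl for nitro without leaving the scatter. No step beyond the scatter is therefore expected in this assay. The expected step is a 1.2-fold lower number from compound 2 to compound 3 (0.08 log units; within the scatter). For compound 3 the estimated value is 35000 nM, with an expected range of 18000 nM to 65000 nM.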

Compound 3, half-maximal inhibitory concentration: 44300 nM
The estimate for compound 3 lay 1.3-fold (0.10 log units) below the measured number, and the stated range covers the measured number.
By their numbers in this assay, from the lowest: compounds 1, 2 and 3 (each within the scatter of the next).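

At the aromatic carbon para to a large group, in this assay, methoxy in place of methyl gives a 1.1-fold higher number from compound 2 to compound 3 (0.03 log units; within the scatter), and methoxy in place of nitro gives a 1.7-fold higher number from compound 1 to compound 3 (0.24 log units; within the scatter). With a third group in place, nitro, methyl and methoxy all lie within the scatter of one another at this position. Nothing measured here bears on why these three groups read alike.

Still open, from the compounds shown here alone, is whether any group at this position leaves the scatter, for example an amine, a carboxylic acid or a longer chain. Also open, going by these compounds, is whether the same holds with changes elsewhere on the shared core.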